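The compounds below may be only part of what the source reports. "The series", "measured", "known", "first", "only" and "open" are said of these compounds alone.

Of the compounds shown here, two have so far been measured in a functional assay on KB cells (Homo sapiens) for antiproliferative activity, read by sulforhodamine B assay, with a stated time of 72 h; a higher number here means a weaker inhibitor, a lower number a stronger inhibitor. Compound 1 `COc1cc(/C=C2\CCC=CC2=O)cc(OC)c1` gives 3630 nM, and compound 2 `COc1cc(/C=C2\CCC=CC2=O)cc(OC)c1OC` gives 880 nM, the lowest of the two numbers. Among the compounds with values here, the only step between them, a 4.1-fold lower number from compound 1 to compound 2 (0.62 log units; beyond the scatter), came from a methoxy in place of hydrogen on an aromatic carbon. Compound 3 `COc1cc(/C=C2\CCC=CC2=O)cc(OC)c1O` differs from compound 2 by hydrogen in place of methyl on an oxygen on an aromatic ring, a change that undoes part of that added methoxy. The earlier step therefore bears on it, and a partial reversal is expected to raise the number moderately, as a step of a 2.0-fold higher number from compound 2 to compound 3 (0.31 log units; beyond the scatter). Compound 3 is estimated at 1800 nM, within 700 nM to 4500 nM.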

Compound 3, half-maximal inhibitory concentration: 1520 nM
Estimate against measurement, compound 3: 1.2-fold (0.07 log units) above, within the range that was stated.
By their numbers in this assay, from the lowest: compounds 2 and 3 (each within the scatter of the next); then compound 1.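

Going from methoxy to hydroxy at this place gives a 1.7-fold higher number from compound 2 to compound 3 (0.24 log units; within the scatter) in this assay and so shows no clear need for the methyl on that oxygen. Hydroxy in place of hydrogen on the aromatic carbon still gives a 2.4-fold lower number from compound 1 to compound 3 (0.38 log units; beyond the scatter) and so, across these three compounds, either oxygen group goes with a lower number than hydrogen.

Going by these compounds, whether a longer chain on that oxygen, such as ethoxy, or an amine or a fluorine on that carbon would behave alike stays open. Nothing at hand accounts for either step.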